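This account rests on a few compounds, and the source may have more. Where it says the series, first, only, none or still open, it means among the compounds named here.

In a functional assay on HL-60 cells (Homo sapiens) for cytotoxicity, read by WST assay, with a stated time of 48 h (on this read-out lower numbers stand for an effect already at smaller amounts and higher numbers for an effect only at larger amounts of compound), compound 1 `O=C1OC[C@H](Cc2ccccc2)[C@H]1Cc1ccccc1C(F)(F)F` gives 37000 nM, and compound 3 `COCOc1cccc(C[C@H]2C(=O)OC[C@@H]2Cc2ccccc2)c1` gives 80000 nM. Compound 2 `O=C1OC[C@H](Cc2ccccc2)[C@H]1Cc1cccc(O)c1` returns only a limit of the assay, > 100000 nM in this assay, which is the limit of > 100000 nM in this assay, at which 1 of the 3 values shown sits. Compound 4 `O=C1OC[C@H](Cc2ccccc2)[C@H]1Cc1ccc(F)cc1` has not been measured; it differs from compound 2 by 4-fluorophenyl in place of 3-hydroxyphenyl on a saturated chain carbon bound to a saturated ring carbon. Going by the values given here, the only measured step from compound 2 is an at least 1.2-fold lower number from compound 2 to compound 3 (0.09 log units; that floor lies within the scatter), a change on the same aromatic ring; compound 1, carrying its own different aromatic group, sits at a measurable number. Since compound 2 stands only at a limit, no step beyond the scatter can be expected with confidence, only a move from the limit into the measurable range. Compound 4 is therefore estimated at 60000 nM, between 20000 nM and 150000 nM, a step of an at least 1.6-fold lower number from compound 2 to compound 4 (0.22 log units; that floor lies within the scatter).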

Compound 4, half-maximal effective concentration: 57000 nM
Beside the measured number, compound 4's estimate is 1.1-fold (0.02 log units) above it; measured number inside the range.
By their numbers in this assay, from the lowest: compounds 1, 4 and 3 (each within the scatter of the next, the first and the last beyond it). At a limit, above all of these: compound 2.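

In this assay the exchange of 3-hydroxyphenyl for 4-fluorophenyl on a saturated chain carbon bound to a saturated ring carbon gives an at least 1.7-fold lower number from compound 2 to compound 4 (0.24 log units; that floor lies within the scatter) and yields a measurable number from a compound that had none. This is the first change shown that replaces the whole aromatic group at this position and removes its hydrogen-bond donor and acceptor. Its size cannot be read exactly, since compound 2 stands at a limit: the limit of > 100000 nM in this assay, at which 1 of the 4 values shown sits.

Going by these compounds, whether the fluorine itself matters remains open. So does what an amine or a carboxylic acid on this aromatic ring, or a longer chain at this position, would do to the number.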